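A few compounds are considered here, and "the series" means these few. Any claim that something is new, unique, unknown or untested is made for them only; others in the source may bear on it.

Measured so far in a functional assay for agonist activity at G protein-coupled receptor 88 (Homo sapiens), read by HTRF and cAMP accumulation; on this read-out higher numbers stand for an effect only at larger amounts of compound and lower numbers for an effect already at smaller amounts:

Compound 1 `CN[C@@H](CC(C)C)CN(C(=O)[C@@H]1C[C@H]1c1ccccc1)c1ccc(-c2ccccc2)cc1`: 2 nM
Compound 2 `CC(C)[C@H](N)CN(C(=O)[C@@H]1C[C@H]1c1ccccc1)c1ccc(-c2ccccc2)cc1`: 1.1 nM
Compound 3 `CO[C@H](C)[C@H](N)CN(C(=O)[C@@H]1C[C@H]1c1ccccc1)c1ccc(-c2ccccc2)cc1`: 0.68 nM

Compound 3 holds the lowest of the three numbers in this assay. Its nearest neighbour is compound 2, since a 1.6-fold lower number from compound 2 to compound 3 (0.21 log units; within the scatter); its furthest is compound 1, since a 2.9-fold lower number from compound 1 to compound 3 (0.47 log units; beyond the scatter). The step from compound 1 to compound 2 was also small: a 1.8-fold lower number from compound 1 to compound 2 (0.26 log units; within the scatter).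

Compound 4 `O=C([C@@H]1C[C@H]1c1ccccc1)N(CC1CCCNC1)c1ccc(-c2ccccc2)cc1` differs from compound 3 in one place: piperidin-3-yl in place of 1-amino-2-methoxypropyl on a saturated chain carbon bound to an amide-type nitrogen. All three measured steps concern changes within the open amine-bearing side chain, and each of them moved the number by little. None of them exchanges that open chain for a ring, so they bear on the step to compound 4 only indirectly. Taken together they suggest that changes in this part of the molecule have so far stayed modest, and compound 4 is therefore expected to give a number in this assay not far from compound 3, with the direction uncertain: a 2.9-fold higher number from compound 3 to compound 4 (0.47 log units; beyond the scatter). The estimate for compound 4 is 2 nM, in a range from 0.5 nM to 8 nM.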

Compound 4, half-maximal effective concentration: 10 nM
Estimate against measurement, compound 4: 5.0-fold (0.70 log units) below, and the stated range ends below it.
By their numbers in this assay, from the lowest: compounds 3, 2 and 1 (each within the scatter of the next, the first and the last beyond it); then compound 4.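

In this assay, replacing an open amine-bearing chain with a ring at this place, on a saturated chain carbon bound to an amide-type nitrogen, gave the first large move seen there: a 15-fold higher number from compound 3 to compound 4 (1.17 log units; beyond the scatter). The same exchange also raised the number against the other two open chains, with a 9.1-fold higher number from compound 2 to compound 4 (0.96 log units; beyond the scatter) and a 5.0-fold higher number from compound 1 to compound 4 (0.70 log units; beyond the scatter), so piperidin-3-yl stands apart from all three, and none of the steps among those open chains reached the size of the largest of these. Nothing at hand explains this difference.

The compounds shown leave open whether the ring itself or the place of its nitrogen sets this number, a question that piperidin-4-yl or pyrrolidin-3-yl would address. Piperidin-3-yl also carries no defined stereocentre here, so whether its two separate mirror-image forms would give different numbers remains open.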